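A few compounds are considered here, and "the series" means these few. Any claim that something is new, unique, unknown or untested is made for them only; others in the source may bear on it.

Compound 2 `CCOC(=O)CNc1nc(Nc2ccccc2)ncc1[N+](=O)[O-]` carries an anilino group on the shared core. In a functional assay on HepG2 cells (Homo sapiens) for antiproliferative activity, read by MTT assay, with a stated time of 48 h (a lower number here means a stronger inhibitor, a higher number a weaker inhibitor), compound 2 gives only a limit, > 100000 nM. Compound 1 `COC(=O)CN(C)c1nc(NCc2ccccc2)ncc1[N+](=O)[O-]` likewise returns a limit in this assay, > 100000 nM. Both results sit at the limit of > 100000 nM in this assay, at which 2 of the 2 values shown sit, so compound 2 stands among values that are limits rather than numbers. Compound 3 `CCOC(=O)CNc1nc(NCc2ccccc2)ncc1[N+](=O)[O-]` differs from compound 2 by benzyl in place of phenyl on a nitrogen on an aromatic ring. Compound 1 also bears a benzylamino group and gives > 100000 nM, so no step beyond the scatter is expected for compound 3. The expected step that the limit leaves unreadable from compound 2 to compound 3 is therefore essentially none. Compound 3 is estimated at 150000 nM, between 50000 nM and 400000 nM.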

Compound 3, half-maximal inhibitory concentration: > 100000 nM
Compound 3 gave a limit, no number; the forecaster's own chance of this, stated with the estimate: 80%; the middle value is on the limit's open side.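

Compound 3, like compound 1 and compound 2, gives only a limit in this assay, so no step to compound 3 can be read: the limit of > 100000 nM in this assay, at which 3 of the 3 values shown sit.

The compounds shown leave open whether anilino and benzylamino differ at all in this assay.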